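A few compounds are considered here, and "the series" means these few. Any claim that something is new, unique, unknown or untested is made for them only; others in the source may bear on it.

Compound 1 `CC/C(=C(/c1ccc(/C=C/C(=O)O)cc1)c1cc2ccccc2[nH]1)c1ccccc1C(F)(F)F` holds the lowest of the three measured numbers: in a functional assay on MCF7 cells (Homo sapiens) for inhibition (a lower number here means a stronger inhibitor, a higher number a weaker inhibitor), compound 1 gives 8 nM. Compound 2 `CC/C(=C(/c1ccc(/C=C/C(=O)O)cc1)c1cc2ccccc2[nH]1)c1cccc(OC(F)(F)F)c1` gives 282 nM and compound 3 `CC/C(=C(/c1ccc(/C=C/C(=O)O)cc1)c1cc2ccccc2[nH]1)c1cccc(F)c1C#N` gives 40 nM, so compound 1 sits below both, nearest to compound 3 and furthest from compound 2. Compound 4 `CC/C(=C(/c1ccc(/C=C/C(=O)O)cc1)c1cc2ccccc2[nH]1)c1cc(Cl)ccc1Cl` differs from compound 1 at one place only: 2,5-dichlorophenyl in place of 2-(trifluoromethyl)phenyl on a double-bonded chain carbon bound to a double-bonded chain carbon and a saturated chain carbon. Among the compounds with values here, two measured steps bear on this change, each swapping the 2-(trifluoromethyl)phenyl group for another aryl group at the same place: a 35-fold higher number from compound 1 to compound 2 (1.55 log units; beyond the scatter) and a 5.0-fold higher number from compound 1 to compound 3 (0.70 log units; beyond the scatter). Both run toward a higher number, the 3-(trifluoromethoxy)phenyl swap being the larger and the 2-cyano-3-fluorophenyl swap the smaller. Within the data shown here, no measured compound carries a dichlorophenyl group, so the size can only be bracketed by these two; a modest rise seems more likely than a large one. Compound 4 is therefore expected to give about 25 nM, within 6 nM to 100 nM. This estimate corresponds to an expected step of a 3.1-fold higher number from compound 1 to compound 4 (0.49 log units; beyond the scatter).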

Compound 4, half-maximal inhibitory concentration: 71 nM
Compound 4: middle estimate off by 2.8-fold (0.45 log units), on the low side; the measured number falls inside the stated range.
By their numbers in this assay, from the lowest: compound 1; then compounds 3 and 4 (each within the scatter of the next); then compound 2.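

In this assay, a third replacement of 2-(trifluoromethyl)phenyl on this double-bonded chain carbon also gives a higher number (an 8.9-fold higher number from compound 1 to compound 4 (0.95 log units; beyond the scatter)), so compound 1 keeps the lowest number against all three other aryl groups shown. The 2,5-dichlorophenyl and 2-cyano-3-fluorophenyl groups cannot be separated in this assay (a 1.8-fold higher number from compound 3 to compound 4 (0.25 log units; within the scatter)), whereas 2,5-dichlorophenyl remains clearly apart from 3-(trifluoromethoxy)phenyl (a 4.0-fold lower number from compound 2 to compound 4 (0.60 log units; beyond the scatter)), so two quite different sets of substituents give results within the scatter of each other. No measured evidence is available to explain these differences.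

The compounds shown leave open where an unsubstituted phenyl or a 2-chlorophenyl group would fall at this place, and so how much each chlorine of compound 4 contributes. They also leave open whether a 2-methoxyphenyl or 2-aminophenyl group would stay close to compound 1.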